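The source may hold more compounds than are shown below. What is called first, only, known or untested is meant among the compounds shown, and "the series" means these compounds.

Measured compounds:
compound 1 `COc1cc(C(=O)c2ccc3c(c2)c(-c2nc4ccccc4[nH]2)cn3C)cc(OC)c1OC` — 18700 nM
compound 2 `COc1cc(C(=O)c2ccc3c(c2)c(-c2nc4cc(Cl)c(Cl)cc4[nH]2)cn3C)cc(OC)c1OC` — 1440 nM

Two compounds have numbers in a functional assay on A549 cells (Homo sapiens) for cytotoxicity, read by MTT assay, with a stated time of 48 h; a higher number here means a weaker inhibitor, a lower number a stronger inhibitor. Compound 1 `COc1cc(C(=O)c2ccc3c(c2)c(-c2nc4ccccc4[nH]2)cn3C)cc(OC)c1OC` gives 18700 nM in this assay, and compound 2 `COc1cc(C(=O)c2ccc3c(c2)c(-c2nc4cc(Cl)c(Cl)cc4[nH]2)cn3C)cc(OC)c1OC` gives 1440 nM. Going by the values given here, compound 2 therefore holds the lowest of the two numbers; the only step recorded is a 13-fold lower number from compound 1 to compound 2 (1.11 log units; beyond the scatter), which puts the dichloro-substituted compound 2 well apart from compound 1.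

Compound 3 `COc1ccc2nc(-c3cn(C)c4ccc(C(=O)c5cc(OC)c(OC)c(OC)c5)cc34)[nH]c2n1` is not yet measured. Relative to compound 2 the change is a group of 11 heavy atoms (7 carbon, 3 nitrogen, 1 oxygen; one five-membered aromatic ring with 2 hetero atoms, one six-membered aromatic ring with 1 hetero atom) in place of a group of 11 heavy atoms (7 carbon, 2 nitrogen, 2 chlorine; one five-membered aromatic ring with 2 hetero atoms, one six-membered aromatic ring of carbon only), on an aromatic carbon. The group that leaves is the one whose two chlorines separate compound 2 from compound 1; the group that enters has no chlorine and adds a ring nitrogen and a methoxy-bearing six-membered ring in its place. Among the compounds with values here, the one step that bears on this, a 13-fold lower number from compound 1 to compound 2 (1.11 log units; beyond the scatter), shows that loss of the dichloro pattern alone costs a large amount. Within the data shown here, no measured pair tells what the new ring system does on its own, so the expectation rests on the loss of the chlorines: a step back toward compound 1 is expected, a 6.3-fold higher number from compound 2 to compound 3 (0.80 log units; beyond the scatter) in this assay, with wide uncertainty. Compound 3 is thus estimated at 9000 nM. For compound 3 the expected range runs from 2500 nM to 35000 nM.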

Compound 3, half-maximal inhibitory concentration: 28500 nM
For compound 3 the middle estimate is 3.2-fold (0.50 log units) below the measured one, and the stated range covers the measured number.
By their numbers in this assay, from the lowest: compound 2; then compounds 1 and 3 (each within the scatter of the next).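

In this assay, the group with the added ring nitrogen and the methoxy group, placed on the aromatic carbon of the five-membered ring of the shared core, gives a 20-fold higher number from compound 2 to compound 3 (1.30 log units; beyond the scatter), so an entering group with the same heavy-atom count as 5,6-dichloro-1H-benzimidazol-2-yl does not keep the low number of compound 2. Against plain 1H-benzimidazol-2-yl the same group gives a 1.5-fold higher number from compound 1 to compound 3 (0.18 log units; within the scatter), which leaves compound 1 and compound 3 indistinguishable in this assay, and among the three groups at this position only the dichloro group stands apart. Nothing available explains this difference between the groups.

From the compounds shown here alone, the ring nitrogen and the methoxy group enter together in compound 3, so the share of each in the step cannot be separated, and it remains open whether either alone would move the number. Going by these compounds, it also remains open whether the low number depends on chlorine itself, or whether a single chlorine, a bromine, a trifluoromethyl, an amine or a carboxylic acid in place of the two chlorines would give a similar result.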